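Bromo for chloro on two different cores

The compounds below may be only part of what the source reports. "The series", "measured", "known", "first", "only" and "open" are said of these compounds alone.

Of the compounds shown here, three have numbers so far. Compound 1 `Oc1ccc(-c2nc3ccc(Cl)cc3s2)cc1` gives, in a functional assay on MCF7 cells (Homo sapiens) for inhibition (a higher number here means a weaker inhibitor, a lower number a stronger inhibitor), 26500 nM. Compound 2 `Oc1ccc(-c2nc3ccc(Br)cc3s2)cc1` gives in this assay 4160 nM, and compound 3 `COc1ccc(-c2nc3cc(F)ccc3s2)cc1Cl` gives in this assay 760 nM, the lowest number of the three. The step from compound 1 to compound 2 is a 6.4-fold lower number from compound 1 to compound 2 (0.80 log units; beyond the scatter); the change behind it is bromo in place of chloro on an aromatic carbon. Compound 3 and compound 1 differ in more than one place, and the difference between the two cores is not broken down here. Compound 3 stands beyond the scatter from both of the others.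

Compound 4 `COc1ccc(-c2nc3cc(F)ccc3s2)cc1Br` has not yet been measured. It differs from compound 3 by bromo in place of chloro on an aromatic carbon. This is the same kind of change as that from compound 1 to compound 2, but the surroundings differ: in compound 1 the carbon is part of a fused or bridged system of two rings, meta to a fused ring and para to a fused ring, whereas in compound 3 it is ortho to a methoxy group and meta to a large group. Going by the values given here, the single earlier instance of this change gave a lower number, so a lower number is expected here as well, though with a core of this kind its size is uncertain and a smaller step is estimated, a 2.2-fold lower number from compound 3 to compound 4 (0.34 log units; beyond the scatter), resting on the step of a 6.4-fold lower number from compound 1 to compound 2 (0.80 log units; beyond the scatter). Compound 4 is therefore estimated at 350 nM in this assay, with a range from 120 nM to 1000 nM.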

Compound 4, half-maximal inhibitory concentration: 850 nM
Compound 4: the middle estimate sits 2.4-fold (0.39 log units) below what was measured; measured number inside the range.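

On the second core, bromo in place of chloro on an aromatic carbon gives a 1.1-fold higher number from compound 3 to compound 4 (0.05 log units; within the scatter), so in this assay the two halogens cannot be told apart at this place, ortho to a methoxy group and meta to a large group. The lower number seen on the first core therefore does not carry over as a fixed step, and the two steps differ by more than repeated measurement would explain: the same change on two cores in this assay, a 6.4-fold lower number (0.80 log units; beyond the scatter) from compound 1 to compound 2 and a 1.1-fold higher number (0.05 log units; within the scatter) from compound 3 to compound 4, 7.1-fold (0.85 log units) apart, beyond the scatter of two such steps. Going by these compounds alone, this shows that, in this series, the size of the step depends on the setting of the change, but with only one pair per core it does not show which difference between the cores matters, whether the halogen's surroundings or some other part of the structure, nor how a third core would behave.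

Still open, on these data alone, is whether either step holds on a core that differs from these two in one place only, such as the core of compound 3 with a hydroxy group in place of the methoxy group, which would separate that group from the other differences between the cores. Also open, as far as these compounds go, is how an amine, a nitrile or a carboxylic acid at the halogen's place would compare with chloro and bromo on the core of compound 3.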